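Chloro for Fluoro on a Fused Aryl Sulfonamide

The source may report more compounds than this note shows. Statements on the series, on what has been measured and on what is new or still open speak of the compounds shown alone.

Three measured compounds share a core carrying a cyclopropyl-substituted oxazole joined to an aryl sulfonamide, and they differ in the fused ring system on the sulfonamide nitrogen. Compound 1 `O=S(=O)(c1ccc(-c2cnc(C3CC3)o2)cc1)N1CCSc2ccccc21` gives 45 nM in a functional assay on HCT-116 cells (Homo sapiens) for antiproliferative activity, read by MTT assay, with a stated time of 72 h; a lower number here means a stronger inhibitor, a higher number a weaker inhibitor. Compound 2 `O=S(=O)(c1ccc(-c2cnc(C3CC3)o2)cc1)N1CCCOc2ccc(F)cc21` gives 24 nM in this assay, the lowest of the three numbers, though its gap to compound 1 lies within the usual scatter, so the two cannot be placed in order. Compound 3 `O=S1(=O)CCCN(S(=O)(=O)c2ccc(-c3cnc(C4CC4)o3)cc2)c2ccccc21` gives 263 nM in this assay, and its gap to compound 2 lies beyond the scatter.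

Compound 4 `O=S(=O)(c1ccc(-c2cnc(C3CC3)o2)cc1)N1CCCOc2ccc(Cl)cc21` has not yet been measured. It differs from compound 2 in one place: chloro in place of fluoro on an aromatic carbon. For the measured compounds named here, no pair of measured compounds shows this kind of exchange, so neither its direction nor its size can be read from the numbers at hand. The account therefore expects only a small step in this assay, a 1.1-fold lower number from compound 2 to compound 4 (0.04 log units; within the scatter), in no particular direction and not beyond the scatter. Compound 4 is accordingly estimated at 22 nM in this assay, within a range from 8 nM to 60 nM.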

Compound 4, half-maximal inhibitory concentration: 39 nM
Compound 4: the middle estimate sits 1.8-fold (0.25 log units) below what was measured; the range from low to high includes it.
By their numbers in this assay, from the lowest: compounds 2, 4 and 1 (each within the scatter of the next); then compound 3.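

In this assay, for the compounds shown here, the exchange of fluoro for chloro on this aromatic carbon gives a 1.6-fold higher number from compound 2 to compound 4 (0.21 log units; within the scatter), the first step that can be read at a single position, since the earlier compounds differ only in their fused ring systems. It shows that this carbon, on the six-membered aromatic ring of the fused system, can carry either chloro or fluoro without the number leaving the scatter, so the two compounds cannot be placed in order and the change has no direction that can be claimed. Nothing at hand gives a measured property of either group that would bear on this result, so the step stands as an observation only.

The compounds shown leave open what a group other than these two halogens, such as an amine, a methoxy or a nitrile, or a plain hydrogen, would do on this same carbon. They also leave open whether chloro in place of fluoro would give as small a step on the fused ring systems of compound 1 or compound 3, or on another carbon of this ring.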